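A few compounds are considered here, and "the series" means these few. Any claim that something is new, unique, unknown or untested is made for them only; others in the source may bear on it.

Measured so far:
- compound 1, `CC(C)(C)N(NC(=O)c1ccccc1F)C(=O)c1ccccc1Cl`, gives 51.3 nM in an assay on cells for agonist activity at ecdysone receptor (Bombyx mori), read by a luciferase reporter, with a stated time of 24 h; a lower number here means that less compound is needed, a higher number that more compound is needed for the effect
- compound 2, `COc1cccc(C(=O)NN(C(=O)c2ccccc2Cl)C(C)(C)C)c1`, gives 52.5 nM in this assay

Both compounds share one core and differ only in the aromatic ring carried on one of the two carbonyl carbons. The step of a 1.0-fold higher number from compound 1 to compound 2 (0.01 log units; within the scatter) shows that exchanging 2-fluorophenyl for 3-methoxyphenyl left the number essentially where it was, so compound 2 sits alongside compound 1 with no separation beyond the scatter.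

The unmeasured compound 3, `CC(C)(C)N(NC(=O)c1ccc(F)cc1)C(=O)c1ccccc1Cl`, keeps the same core and changes that ring once more: 4-fluorophenyl in place of 3-methoxyphenyl on a carbonyl carbon. Within the data shown here, the only step known here, from compound 1 to compound 2, concerns the same ring on the same carbonyl carbon and stayed within the scatter. Among the measured compounds shown here, there is no measured step that involves 4-fluorophenyl itself. With that single comparison as the guide, the expectation for compound 3 is a step of about a 1.0-fold lower number from compound 2 to compound 3 (0.00 log units; within the scatter) in this assay, that is, no movement beyond the scatter. Compound 3 is therefore estimated at 52 nM, with a range from 20 nM to 140 nM.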

Compound 3, half-maximal effective concentration: 389 nM
Compound 3: the middle estimate sits 7.5-fold (0.87 log units) below what was measured, and the stated range ends below it.
By their numbers in this assay, from the lowest: compounds 1 and 2 (each within the scatter of the next); then compound 3.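

The ring on this carbonyl carbon is not as forgiving as the first two compounds suggested: in this assay, 2-fluorophenyl and 3-methoxyphenyl gave numbers within the scatter of each other, whereas 4-fluorophenyl gives a 7.4-fold higher number from compound 2 to compound 3 (0.87 log units; beyond the scatter) and thus needs clearly more compound for the effect. The comparison with the fluorine-bearing ring of compound 1 is the more telling one, since 2-fluorophenyl and 4-fluorophenyl differ only in where the fluorine sits on the ring, yet the exchange still gives a 7.6-fold higher number from compound 1 to compound 3 (0.88 log units; beyond the scatter), so carrying a fluorine does not by itself set the number in this small set. No measurement offered here accounts for this shift.

The three compounds leave open whether the higher number goes with fluorine in particular or with any group in the 4 position, which 4-chlorophenyl or 4-methoxyphenyl could help to separate, and where plain phenyl or 3-fluorophenyl would stand. They also leave open whether the same pattern would hold if the rest of the shared core were changed, since all three compounds keep it unaltered.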